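From dimethylamino to fluoro on compound 2

The source may report more compounds than this note shows. Statements on the series, on what has been measured and on what is new or still open speak of the compounds shown alone.

Measured so far in an ADME assay on HEp-2 cells (Homo sapiens) for cytotoxicity; on this read-out higher numbers stand for lower toxicity in this test and lower numbers for higher toxicity in this test:
Compound 1 `C=C(C)n1c(=O)n(Cc2nc3ccccc3n2CCC(C)C)c2ccccc21` gives 24600 nM
Compound 2 `CC(C)CCn1c(Cn2c(=O)n(C(C)C)c3ccccc32)nc2cc(CN(C)C)ccc21` gives 5650 nM
Compound 3 `CC(C)CCn1c(Cn2c(=O)n(CC(=O)O)c3ccccc32)nc2cc(C(=N)N)ccc21` gives 173000 nM

Compound 2 holds the lowest number of the three, and both others lie beyond the scatter above it. Compound 1 is the nearest and compound 3 the furthest. Compound 4 `CC(C)CCn1c(Cn2c(=O)n(C(C)C)c3ccccc32)nc2cc(CF)ccc21` has not yet been measured. It departs from compound 2 by a single change, fluoro in place of dimethylamino on a saturated chain carbon bound to an aromatic carbon.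

Among the measured compounds shown here, no measured pair isolates this change, so its size can only be judged indirectly. Compound 1, which has no dimethylamino group, gives 24600 nM and compound 3, also without one, gives 173000 nM, but each differs from compound 2 in other places too. On that limited ground, a rise beyond the scatter is expected in this assay. The expected step is a 3.2-fold higher number from compound 2 to compound 4 (0.50 log units; beyond the scatter) on this reading. Compound 4 is estimated at 18000 nM (range 6000 nM to 55000 nM).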

Compound 4, half-maximal cytotoxic concentration: 37300 nM
The estimate for compound 4 lay 2.1-fold (0.32 log units) below the measured number, within the range that was stated.
By their numbers in this assay, from the lowest: compound 2; then compounds 1 and 4 (each within the scatter of the next); then compound 3.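

Within this assay the change of dimethylamino to fluoro, on a saturated chain carbon bound to an aromatic carbon, gives a 6.6-fold higher number from compound 2 to compound 4 (0.82 log units; beyond the scatter) and so provides the one direct reading of this position, which the earlier compounds could not give as they differ from compound 2 in other places too. The step shows that this single change, with the rest of compound 2 left as it is, moves the number beyond the scatter towards lower toxicity in this test. Nothing available accounts for the size of this step.

Whether the rise comes from the loss of dimethylamino or the arrival of fluoro stays open, as no other group, such as a hydroxyl, a methyl or a primary amine, is shown on this carbon. Also open, on these data alone, is whether the step would hold with a carboxylic acid elsewhere on the shared core.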